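The source may hold more compounds than are shown below. What is called first, only, known or untested is meant among the compounds shown, and "the series" means these compounds.

Compound 3 `Cc1ccc(C(=O)Nc2sc3c(c2C(N)=O)CCN(C(=S)Nc2ccccc2Cl)C3)cc1` carries a thiourea on the ring nitrogen of the shared core, and in a functional assay on HL-60 cells (Homo sapiens) for antiproliferative activity, with a stated time of 24 h (on this read-out higher numbers stand for weaker inhibition and lower numbers for stronger inhibition), compound 3 gives 8430 nM, the lowest of the two numbers recorded here. Compound 1 `NC(=O)c1c(NC(=O)c2ccccc2F)sc2c1CCN(C(=O)Nc1ccccc1Cl)C2`, a urea with a 2-fluorophenyl group on the carbonyl carbon, gives 32700 nM in this assay, a higher number that lies beyond the scatter. Compound 2 `NC(=O)c1c(NC(=O)c2ccc(C(F)(F)F)cc2)sc2c1CCN(C(=O)Nc1ccccc1Cl)C2`, with a 4-(trifluoromethyl)phenyl group in that place, gives in this assay only > 50000 nM, which is a limit of the assay and not a number. The step of an at least 1.5-fold higher number from compound 1 to compound 2 (0.18 log units; that floor lies within the scatter) therefore rests on (the limit of > 50000 nM in this assay, at which 1 of the 3 values shown sits).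

Compound 4 `Cc1ccc(C(=O)Nc2sc3c(c2C(N)=O)CCN(C(=O)Nc2ccccc2Cl)C3)cc1` differs from compound 3 by a group of 10 heavy atoms (7 carbon, 1 nitrogen, 1 oxygen, 1 chlorine; one six-membered aromatic ring of carbon only) in place of a group of 10 heavy atoms (7 carbon, 1 nitrogen, 1 sulfur, 1 chlorine; one six-membered aromatic ring of carbon only), on an amine nitrogen in a ring. Going by the values given here, no measured step touches this part of the molecule; the only measured step, an at least 1.5-fold higher number from compound 1 to compound 2 (0.18 log units; that floor lies within the scatter), alters the aryl group on the carbonyl instead. Both ureas, compounds 1 and 2, sit at weak values, while the thiourea compound 3 is stronger, though the aryl groups also differ. Compound 4 is expected to show a 2.6-fold higher number from compound 3 to compound 4 (0.42 log units; beyond the scatter) in this assay. The estimate for compound 4 is 22000 nM, ranging from 7000 nM to 60000 nM.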

Compound 4, half-maximal inhibitory concentration: 14600 nM
Compound 4: middle estimate off by 1.5-fold (0.18 log units), on the high side, and the stated range covers the measured number.
By their numbers in this assay, from the lowest: compounds 3 and 4 (each within the scatter of the next); then compound 1. At a limit, above all of these: compound 2.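

Putting the urea in place of the thiourea on the amine nitrogen in a ring gives a 1.7-fold higher number from compound 3 to compound 4 (0.24 log units; within the scatter), so sulfur and oxygen at this place cannot be told apart in this assay. With the urea kept, methyl in place of trifluoromethyl on an aromatic carbon gives an at least 3.4-fold lower number from compound 2 to compound 4 (0.53 log units; beyond the scatter), a minimum size that rests on a limit of the assay: the limit of > 50000 nM in this assay, at which 1 of the 4 values shown sits. Likewise, 4-methylphenyl in place of 2-fluorophenyl on a carbonyl carbon gives a 2.2-fold lower number from compound 1 to compound 4 (0.35 log units; beyond the scatter), so in these compounds the clear changes come from the aryl group on the carbonyl, not from the thiourea-to-urea swap.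

All four compounds keep the 2-chlorophenyl group on the urea or thiourea. Going by these compounds, whether a longer alkyl chain in its place, or an amine or a carboxylic acid in place of the methyl, would shift the number stays open.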